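Carbonyl substituent swap on the aminomethyl-bearing analogue

A few compounds are considered here, and "the series" means these few. Any claim that something is new, unique, unknown or untested is made for them only; others in the source may bear on it.

Compound 2 `CN(C)CC1CCC/C(=C\c2ccc(OC(=O)/C=C/c3ccc(F)cc3)cc2)C1=O` holds the lowest number among the three measured compounds in a functional assay on L1210 cells (Mus musculus) (a lower number here means a stronger inhibitor, a higher number a weaker inhibitor), where compound 2 gives 1840 nM. Among the measured compounds shown here, compound 1 `O=C(/C=C/c1ccc(F)cc1)Oc1ccc(/C=C2\CCCCC2=O)cc1` lacks the (dimethylamino)methyl group on the saturated ring; in this assay compound 1 gives 30900 nM, and the step of a 17-fold lower number from compound 1 to compound 2 (1.23 log units; beyond the scatter) is the only step between compounds that differ in one place. Compound 3 `COc1ccc(C(=O)Oc2ccc(/C=C3\CCCCC3=O)cc2)cc1` carries a different group on the carbonyl carbon and in this assay compound 3 gives 43400 nM. Compounds 1 and 3 differ at the carbonyl carbon in more than one place, so their two values are simply placed side by side: they lie close to one another.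

Compound 4 `CN(C)CC1CCC/C(=C\c2ccc(OC(=O)c3ccc(Cl)cc3)cc2)C1=O` keeps the (dimethylamino)methyl group of compound 2 and changes the carbonyl end: 4-chlorophenyl in place of 2-(4-fluorophenyl)ethenyl on a carbonyl carbon. For the measured compounds named here, no measured step touches this site; the step of a 17-fold lower number from compound 1 to compound 2 (1.23 log units; beyond the scatter) concerns the saturated ring only. The nearest guide is the pair of compounds 1 and 3, whose values sit close together despite different carbonyl substituents. The expectation for compound 4 is therefore a step not beyond the scatter, a 1.4-fold higher number from compound 2 to compound 4 (0.13 log units; within the scatter). Compound 4 is estimated at 2500 nM, with a range from 800 nM to 8000 nM.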

Compound 4, half-maximal inhibitory concentration: 5610 nM
Beside the measured number, compound 4's estimate is 2.2-fold (0.35 log units) below it, within the range that was stated.
By their numbers in this assay, from the lowest: compound 2; then compound 4; then compounds 1 and 3 (each within the scatter of the next).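

Notes on the carbonyl carbon: in this assay this site now has a step of its own, a 3.0-fold higher number from compound 2 to compound 4 (0.48 log units; beyond the scatter) with 4-chlorophenyl in place of 2-(4-fluorophenyl)ethenyl. The site therefore responds to substitution when the (dimethylamino)methyl group is present, even though an aromatic ring of carbon only remains in the entering group and the double bond outside aromatic rings is lost; this step is still smaller than a 17-fold lower number from compound 1 to compound 2 (1.23 log units; beyond the scatter) at the saturated ring. No supporting data bear on why the exchange moves the number, and the shift stands here as an observation only.

The exchange alters the double bond and the halogen together, so the compounds shown do not separate the two changes; 4-fluorophenyl or 2-(4-chlorophenyl)ethenyl on the carbonyl carbon would be needed to tell them apart. Also open, from the compounds shown here alone, is how the 4-methoxyphenyl group of compound 3 behaves with the (dimethylamino)methyl group on the saturated ring, and whether a morpholine in place of the dimethylamine keeps the gain seen at that ring.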